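Chloro for methyl on the benzylsulfanyl arm

The compounds below may be only part of what the source reports. "The series", "measured", "known", "first", "only" and "open" are said of these compounds alone.

Of the compounds shown here, three on the shared core have been measured in a functional assay on HCT-116 cells (Homo sapiens) for cytotoxicity, read by MTT assay, with a stated time of 72 h; a higher number here means a weaker inhibitor, a lower number a stronger inhibitor. Compound 1 `Cc1cc(S(=O)(=O)/N=C(\N)n2nccc2-c2ccccc2)c(SCc2ccc(C(F)(F)F)cc2)cc1Cl` gives 14000 nM. Compound 2 `Cc1cc(S(=O)(=O)/N=C(\N)n2nccc2-c2ccccc2)c(SCc2cccc(C(F)(F)F)c2)cc1Cl` gives 14000 nM, and compound 3 `Cc1ccc(CSc2cc(Cl)c(C)cc2S(=O)(=O)/N=C(\N)n2nccc2-c2ccccc2)cc1` gives 14000 nM. Compound 3 thus stands level with the other two at the digits recorded, nearest to compound 1 and no further from compound 2. The step of no change at the digits printed from compound 1 to compound 2 (within the scatter) lies within the scatter, as do no change at the digits printed from compound 1 to compound 3 (within the scatter) and no change at the digits printed from compound 2 to compound 3 (within the scatter). In this small set the group on the saturated chain carbon bound to a sulfur has so far made no difference that the measurement can resolve.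

Compound 4 `Cc1cc(S(=O)(=O)/N=C(\N)n2nccc2-c2ccccc2)c(SCc2ccc(Cl)cc2)cc1Cl` is the next member. Against compound 3 the change is chloro in place of methyl on an aromatic carbon. Among the compounds with values here, no measured step covers exactly this exchange; the ones that bear on it are the three at the same arm, and all three stayed within the scatter. Given no change at the digits printed from compound 1 to compound 2 (within the scatter), no change at the digits printed from compound 1 to compound 3 (within the scatter) and no change at the digits printed from compound 2 to compound 3 (within the scatter) across that arm, no step beyond the scatter is expected from no change at the digits printed from compound 3 to compound 4 (within the scatter). Compound 4 is therefore estimated at 14000 nM, with a range from 7000 nM to 28000 nM.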

Compound 4, half-maximal inhibitory concentration: 7000 nM
Beside the measured number, compound 4's estimate is 2.0-fold (0.30 log units) above it, and the stated range covers the measured number.
By their numbers in this assay, from the lowest: compounds 4, 1, 2 and 3 (each within the scatter of the next).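

The arm now carries chloro as well as methyl and trifluoromethyl. In this assay the exchange of methyl for chloro gives a 2.0-fold lower number from compound 3 to compound 4 (0.30 log units; within the scatter) and the exchange of trifluoromethyl for chloro gives a 2.0-fold lower number from compound 1 to compound 4 (0.30 log units; within the scatter), while the change of 3-(trifluoromethyl)phenyl to 4-chlorophenyl gives a 2.0-fold lower number from compound 2 to compound 4 (0.30 log units; within the scatter). Within the data shown here, this is the first step that moves the printed digits, but it stays within the scatter, so a halogen on this aromatic carbon joins the two carbon-based groups with no difference the measurement can resolve, and all four compounds remain within the scatter of one another. No data are at hand that bear on the origin of this small shift in the number.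

Still open, as far as these compounds go, is whether a more different group on the same aromatic carbon, such as an amine, a hydroxyl or a carboxylic acid, would give a step beyond the scatter. Equally open is whether a longer chain between the sulfur and the aromatic ring would do so, and the compounds shown say nothing about changes elsewhere on the shared core.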